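From hydroxy to nitro in compound 4

The compounds below may be only part of what the source reports. "The series", "measured", "known", "first", "only" and "open" are said of these compounds alone.

In a functional assay on SGC-7901 cells (Homo sapiens) for antiproliferative activity, read by MTT assay, with a stated time of 72 h (on this read-out higher numbers stand for weaker inhibition and lower numbers for stronger inhibition), compound 3 `COc1ccc(-c2ssc(=O)c2-c2cc(OC)c(OC)c(OC)c2)cc1O` reads 3110 nM and lies within the scatter of compound 1 `COc1ccc(-c2c(-c3cc(OC)c(OC)c(OC)c3)ssc2=S)cc1N` at 2620 nM on this scale. Compound 2 `COc1ccc(-c2ssc(=O)c2-c2cc(OC)c(OC)c(OC)c2)cc1` at 134 nM lies far lower than both. Compound 4 `COc1ccc(-c2ssc(=O)c2-c2cc(OC)c(OC)c(OC)c2)cc1[N+](=O)[O-]` is still unmeasured: it carries nitro in place of hydroxy on an aromatic carbon, ortho to a methoxy group (nitro in place of hydroxy on an aromatic carbon). For the measured compounds named here, the one measured change at this carbon, hydroxy in place of hydrogen, was large and beyond the scatter (a 23-fold higher number from compound 2 to compound 3 (1.37 log units; beyond the scatter)). Nitro also removes the hydroxy, but it is a different group, so only partial recovery toward compound 2 at 134 nM is expected. In this assay the estimated move is a moderate one toward a lower number (a 3.5-fold lower number from compound 3 to compound 4 (0.54 log units; beyond the scatter)). The estimate for compound 4 is 900 nM (range 170 nM to 4500 nM).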

Compound 4, half-maximal inhibitory concentration: 440 nM
Compound 4: middle estimate off by 2.0-fold (0.31 log units), on the high side, within the range that was stated.
By their numbers in this assay, from the lowest: compound 2; then compound 4; then compounds 1 and 3 (each within the scatter of the next).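

In this assay, replacing hydroxy with nitro on this carbon gives a 7.1-fold lower number from compound 3 to compound 4 (0.85 log units; beyond the scatter), so a group here need not cost as much as hydroxy did. Even so, nitro in place of hydrogen gives a 3.3-fold higher number from compound 2 to compound 4 (0.52 log units; beyond the scatter), which means that both groups seen on this carbon read higher than plain hydrogen. No available evidence explains the gap between nitro and hydroxy. Still open, as far as these compounds go, is how a nitrile or a single fluorine atom on this same carbon would read, and whether any group here can match or improve on hydrogen.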